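Swapping the Fluorine for Methoxy on the Aryl Group

This account rests on a few compounds, and the source may have more. Where it says the series, first, only, none or still open, it means among the compounds named here.

Two compounds share one core. Compound 1 `Cc1nc(-c2cc3ccccc3o2)sc1COc1ccc2c(c1)OCC2CC(=O)O` bears a different aromatic group on that core, but no result was reported for it: in a functional assay on CHO cells for agonist activity at Free fatty acid receptor 1 (Homo sapiens), read by FLIPR and calcium flux (on this read-out lower numbers stand for an effect already at smaller amounts and higher numbers for an effect only at larger amounts of compound), compound 1 gives "not determined" (no result reported). Among the compounds with values here, compound 2 `Cc1nc(-c2cccc(F)c2)sc1COc1ccc2c(c1)OCC2CC(=O)O` is the only compound with a number: in this assay compound 2 gives 64.8 nM. Compound 3 `COc1ccc(-c2nc(C)c(COc3ccc4c(c3)OCC4CC(=O)O)s2)cc1` differs from compound 2 by 4-methoxyphenyl in place of 3-fluorophenyl on an aromatic carbon. Within the data shown here, with no measured pair to lean on, the step from compound 2 to compound 3 is expected to be small, perhaps slightly toward larger amounts of compound, and possibly within the usual scatter: a 1.5-fold higher number from compound 2 to compound 3 (0.19 log units; within the scatter). Compound 3 is therefore estimated at 100 nM in this assay, with a likely range from 30 nM to 350 nM.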

Compound 3, half-maximal effective concentration: 123 nM
The estimate for compound 3 lay 1.2-fold (0.09 log units) below the measured number; the measured number falls inside the stated range.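

In this assay the swap gives a 1.9-fold higher number from compound 2 to compound 3 (0.28 log units; within the scatter). This first measured pair shows that, on this aromatic carbon of the five-membered ring, 4-methoxyphenyl with its one hydrogen-bond acceptor and 3-fluorophenyl cannot be told apart. No measurement shown accounts for this.

The two groups differ both in the substituent and in where it sits on the phenyl ring, so these two changes cannot be separated here. Going by these compounds, how a phenyl ring carrying an amine or a nitrile would read remains open.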